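Replacing the oxadiazole with acetyl on the shared core

This account rests on a few compounds, and the source may have more. Where it says the series, first, only, none or still open, it means among the compounds named here.

In an ADME assay on the whole organism (Rattus norvegicus) for metabolic stability, at a dose of 1 mg/kg by the intravenous route (on this read-out higher numbers stand for a longer-lived compound and lower numbers for a shorter-lived compound), compound 1 `O=C(c1cnco1)N1CCC(C(=O)N2N=CC[C@H]2c2ccccc2)CC1` gives 0.467 h and compound 2 `Cc1nnc(N2CCC(C(=O)N3N=CC[C@H]3c3ccccc3)CC2)o1` gives 1 h, so compound 2 holds the higher of the two numbers. Compound 3 `CC(=O)N1CCC(C(=O)N2N=CC[C@H]2c2ccccc2)CC1` has not yet been measured. It carries acetyl in place of 5-methyl-1,3,4-oxadiazol-2-yl on an amine nitrogen in a ring. Going by the values given here, one measured step bears on this change, the modest 2.1-fold higher number from compound 1 to compound 2 (0.33 log units; beyond the scatter), which put 5-methyl-1,3,4-oxadiazol-2-yl in place of (1,3-oxazol-5-yl)carbonyl on that same nitrogen. Compound 3 again has a carbonyl group there, as compound 1 does, so a step no larger than that one, towards a lower number and possibly within the scatter, is expected. The expected step is a 1.4-fold lower number from compound 2 to compound 3 (0.15 log units; within the scatter). Compound 3 is estimated at 0.7 h, with an expected range from 0.3 h to 1.5 h.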

Compound 3, half-life: 0.85 h
Compound 3: middle estimate off by 1.2-fold (0.08 log units), on the low side; the range from low to high includes it.
By their numbers in this assay, from the lowest: compounds 1, 3 and 2 (each within the scatter of the next, the first and the last beyond it).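

In this assay, compound 3 shows that a ring on this amine nitrogen is not required to hold the half-life at the level of compound 2: acetyl, which has no ring, replaces 5-methyl-1,3,4-oxadiazol-2-yl with a step within the scatter (a 1.2-fold lower number from compound 2 to compound 3 (0.07 log units; within the scatter)). Methyl in place of 1,3-oxazol-5-yl on a carbonyl carbon also stays within the scatter (a 1.8-fold higher number from compound 1 to compound 3 (0.26 log units; within the scatter)). Going by these compounds alone, the only step here beyond the scatter therefore remains the earlier one (a 2.1-fold higher number from compound 1 to compound 2 (0.33 log units; beyond the scatter)), and compound 3 cannot be separated from either of the other two compounds.

Going by these compounds, whether a longer acyl chain, a sulfonyl group or a free amine on this nitrogen would stay within the same span remains open, as does the effect of changes elsewhere on the shared core. Nothing shown here explains any of these steps.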